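Fluoro for hydrogen on the anilide ring of compound 2

The source may hold more compounds than are shown below. What is called first, only, known or untested is meant among the compounds shown, and "the series" means these compounds.

Series of aminotriazole thioethers carrying a trimethoxyphenyl group, tested in a functional assay on PC-3 cells (Homo sapiens) for antiproliferative activity, read by MTT assay, with a stated time of 48 h; on this read-out higher numbers stand for weaker inhibition and lower numbers for stronger inhibition. Compound 1 `COc1cc(-c2nnc(SCC(=O)c3ccc(C)cc3)n2N)cc(OC)c1OC` gives 31300 nM in this assay. Among the compounds with values here, compound 2 `COc1cc(-c2nnc(SCC(=O)Nc3ccccc3)n2N)cc(OC)c1OC` gives 37900 nM in this assay, the highest of the two numbers so far; its nearest neighbour is compound 1, and the step of a 1.2-fold higher number from compound 1 to compound 2 (0.08 log units; within the scatter) shows the two as indistinguishable. Compound 3 `COc1cc(-c2nnc(SCC(=O)Nc3ccccc3F)n2N)cc(OC)c1OC` is the next analogue, not yet measured. The change from compound 2 to compound 3 is fluoro in place of hydrogen on an aromatic carbon, read one bond further out as phenyl to 2-fluorophenyl. Within the data shown here, no measured step concerns a fluoro substituent; the only step available, from compound 1 to compound 2, changes the group on the carbonyl carbon and is within the scatter. With nothing to point either way, compound 3 is expected to sit close to compound 2, with the step of a 1.1-fold lower number from compound 2 to compound 3 (0.02 log units; within the scatter) estimated to lie within the scatter. The estimate for compound 3 in this assay is 36000 nM, with a range from 15000 nM to 85000 nM.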

Compound 3, half-maximal inhibitory concentration: 36700 nM
The estimate for compound 3 lay 1.0-fold (0.01 log units) below the measured number; measured number inside the range.
By their numbers in this assay, from the lowest: compounds 1, 3 and 2 (each within the scatter of the next).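

Fluoro in place of hydrogen on an aromatic carbon, ortho to a large group, gives a 1.0-fold lower number from compound 2 to compound 3 (0.01 log units; within the scatter) in this assay and so leaves phenyl and 2-fluorophenyl unseparated at this position. The second comparison, a 1.2-fold higher number from compound 1 to compound 3 (0.07 log units; within the scatter) for (2-fluorophenyl)amino in place of 4-methylphenyl on the carbonyl carbon, shows that the two groups on the carbonyl carbon stay unseparated with the fluoro present, as they were without it. Nothing available explains the absence of a readable step and no cause can be assigned.

Open, as far as these compounds go, is whether a larger substituent on this ring, such as methoxy, nitro or a carboxylic acid, would produce a step beyond the scatter. Also open, from the compounds shown here alone, is how a longer chain between the sulfur and the carbonyl, or replacement of the amino group on the shared core, would read.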